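This account rests on a few compounds, and the source may have more. Where it says the series, first, only, none or still open, it means among the compounds named here.

Among the compounds with values here, in a functional assay on MCF7 cells (Homo sapiens) for inhibition, read by MTT assay, with a stated time of 72 h (a higher number here means a weaker inhibitor, a lower number a stronger inhibitor), compound 2 `COc1cc2c(Oc3ccc(NC(=O)c4nn(-c5ccc(F)c(Cl)c5)cc(C)c4=O)cc3)ccnc2cc1OCCCCCCC(=O)NO` gives 2200 nM, the higher of the two numbers measured so far, though the gap to compound 1 lies within the scatter. Compound 1 `COc1cc2c(Oc3ccc(NC(=O)c4nn(-c5ccccc5C)cc(C)c4=O)cc3)ccnc2cc1OCCCC(=O)NO` gives 1600 nM in this assay. Compound 3 `COc1cc2c(Oc3ccc(NC(=O)c4nn(-c5ccccc5)cc(C)c4=O)cc3)ccnc2cc1OCCCCCCC(=O)NO` differs from compound 2 at one place: phenyl in place of 3-chloro-4-fluorophenyl on an aromatic nitrogen. Within the data shown here, no measured pair separates these two groups, so the direction of the step is open, and nothing beyond the scatter is expected in either direction. The step estimated here is a 1.1-fold higher number from compound 2 to compound 3 (0.06 log units; within the scatter). Compound 3 is expected near 2500 nM, within a range of 1000 nM to 6500 nM.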

Compound 3, half-maximal inhibitory concentration: 1610 nM
The estimate for compound 3 lay 1.6-fold (0.19 log units) above the measured number; the measured number falls inside the stated range.
By their numbers in this assay, from the lowest: compounds 1, 3 and 2 (each within the scatter of the next).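

In this assay, replacing 3-chloro-4-fluorophenyl with phenyl on the aromatic nitrogen gives a 1.4-fold lower number from compound 2 to compound 3 (0.14 log units; within the scatter). Within the data shown here, this is the first pair to isolate this position, and it does not separate the two groups, so the two halogens make no difference beyond the scatter here. No measured evidence bears on this result, and it offers no explanation for it. On these data alone, whether a pyridyl ring, a methoxy group or an amine on the phenyl ring would shift the number remains open. As far as these compounds go, the effect of this swap with a different chain attached is also open.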